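Cyclohexylmethyl replacing pyridinylmethyl on the aromatic nitrogen

The compounds below may be only part of what the source reports. "The series", "measured", "known", "first", "only" and "open" are said of these compounds alone.

Compound 1 `CS(=O)(=O)Nc1ccc2c(c1)S(=O)(=O)C=C(c1c(O)c3cc(F)ccc3n(Cc3ccccc3)c1=O)N2` carries a benzyl group on the aromatic nitrogen of the shared core. In an ADME assay on 2209-23 cells (Homo sapiens) for cytotoxicity, read by WST assay (a lower number here means that less compound is tolerated, a higher number that more compound is tolerated), compound 1 gives only a limit of the assay, > 50000 nM. Compound 2 `CS(=O)(=O)Nc1ccc2c(c1)S(=O)(=O)C=C(c1c(O)c3cc(F)ccc3n(Cc3cccnc3)c1=O)N2` differs by pyridin-3-yl in place of phenyl on a saturated chain carbon bound to an aromatic nitrogen. In this assay compound 2 likewise gives only a limit, > 50000 nM. The step that the two limits leave unreadable from compound 1 to compound 2 is therefore not readable, as both values sit at the limit of > 50000 nM in this assay, at which 2 of the 2 values shown sit.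

Compound 3 `CS(=O)(=O)Nc1ccc2c(c1)S(=O)(=O)C=C(c1c(O)c3cc(F)ccc3n(CC3CCCCC3)c1=O)N2` carries the change (cyclohexyl in place of pyridin-3-yl on a saturated chain carbon bound to an aromatic nitrogen); cut one bond further out, it reads (pyridin-3-yl)methyl to cyclohexylmethyl. For the measured compounds named here, the only measured step, from compound 1 to compound 2, is unreadable and bears on this change only in that both earlier compounds were tolerated up to the limit of this assay. Going by the values given here, no step of readable size in this assay is thus available to set a direction. The expectation for compound 3 is that the step that the limit leaves unreadable from compound 2 to compound 3 stays unreadable in this assay. Compound 3 is estimated at 80000 nM, in the range 30000 nM to 250000 nM.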

Compound 3, half-maximal cytotoxic concentration: > 50000 nM
Compound 3: only a limit was reported (the forecaster's own chance of this, stated with the estimate: 75%); the middle value is on the limit's open side.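

In this assay compound 3 gives only a limit, > 50000 nM. The steps from compound 1 and from compound 2 to compound 3 therefore cannot be read: the limit of > 50000 nM in this assay, at which 3 of the 3 values shown sit.

The compounds shown leave open whether phenyl, pyridin-3-yl and cyclohexyl differ at all in this assay, with no value yet lying inside the range of the read-out.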